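The source may hold more compounds than are shown below. What is called first, only, known or untested is meant among the compounds shown, and "the series" means these compounds.

Series notes. Compound 1 `N#C/N=C1\N(CCCCCCOc2ccc(Cl)cc2)C(=O)C(c2ccccc2)N1c1ccncc1` and compound 2 `N#C/N=C1\N(CCCCCCCOc2ccc(Cl)cc2)C(=O)C(c2ccccc2)N1c1ccncc1` share one core; compound 3 `N#C/N=C1\N(CCCCCOc2ccc(Cl)cc2)C(=O)CCN1c1ccncc1` and compound 4 `N#C/N=C1\N(CCCCCCOc2ccc(Cl)cc2)C(=O)CCN1c1ccncc1` share another, and the difference between the two cores is not broken down here. In a functional assay on HONE1 cells for cytotoxicity against HONE1 cell line (Homo sapiens) (on this read-out lower numbers stand for stronger inhibition and higher numbers for weaker inhibition), compound 1 gives 337 nM and compound 2 gives 398 nM; the step of a 1.2-fold higher number from compound 1 to compound 2 (0.07 log units; within the scatter) follows from (4-chlorophenoxy)methyl in place of 4-chlorophenoxy on a saturated chain carbon, six bonds along the chain from an amide-type nitrogen in a ring. Compound 3 gives 3450 nM in this assay, the highest number of the three measured. Compound 4 is related to compound 3 by (4-chlorophenoxy)methyl in place of 4-chlorophenoxy on a saturated chain carbon, five bonds along the chain from an amide-type nitrogen in a ring, the same kind of change as that from compound 1 to compound 2, though here made on a saturated chain carbon five bonds along the chain from an amide-type nitrogen in a ring rather than six bonds along it. The step is expected to be small, a 1.1-fold higher number from compound 3 to compound 4 (0.04 log units; within the scatter), because the earlier one was a 1.2-fold higher number from compound 1 to compound 2 (0.07 log units; within the scatter). Compound 4 is therefore estimated at 3800 nM in this assay, within 1700 nM to 8500 nM.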

Compound 4, half-maximal inhibitory concentration: 577 nM
Compound 4: the middle estimate sits 6.6-fold (0.82 log units) above what was measured, and the stated range ends above it.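

In this assay, the change from 4-chlorophenoxy to (4-chlorophenoxy)methyl does not carry over from one core to the other at a constant size: the same change on two cores in this assay, a 1.2-fold higher number (0.07 log units; within the scatter) from compound 1 to compound 2 and a 6.0-fold lower number (0.78 log units; beyond the scatter) from compound 3 to compound 4, 7.1-fold (0.85 log units) apart, beyond the scatter of two such steps

On the core of compound 3 the new step is a 6.0-fold lower number from compound 3 to compound 4 (0.78 log units; beyond the scatter), so a small step on the core of compound 1 gives no safe estimate for this core. This rests on one pair per core, and the change sits five bonds along the chain in one pair and six bonds along it in the other, so the core and the place cannot be separated.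

Still open, going by these compounds, is whether a longer chain on the core of compound 3 holds the number seen for compound 4. Also open, on these data alone, is whether a shorter chain on the core of compound 1 gives a similar step, and how an amine in place of 4-chlorophenoxy would read.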